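Phenyl for 4-methylbenzyl on the amide-type nitrogen

The compounds below may be only part of what the source reports. "The series", "measured", "known", "first", "only" and "open" are said of these compounds alone.

In a functional assay on K562 cells (Homo sapiens) for cytotoxicity, read by MTT assay, with a stated time of 48 h (on this read-out lower numbers stand for stronger inhibition and higher numbers for weaker inhibition), compound 1 (`COc1cc([C@H]2C[C@@]2(CO)C(=O)Nc2ccccc2)cc(OC)c1OC`) gives > 100000 nM as a limit and not a number. Compound 2 (`COc1cc([C@H]2C[C@]2(CO)C(=O)Nc2ccccc2Cl)cc(OC)c1OC`) gives > 100000 nM as a limit too. Compound 3 (`COc1cc([C@H]2C[C@]2(CO)C(=O)NCc2ccc(C)cc2)cc(OC)c1OC`) gives > 100000 nM as a limit as well. Compound 3 thus stands with the other two at the limit of > 100000 nM in this assay, at which 3 of the 3 values shown sit, and no measured number exists in the series. Compound 4 (`COc1cc([C@H]2C[C@]2(CO)C(=O)Nc2ccccc2)cc(OC)c1OC`) has phenyl in place of 4-methylbenzyl on an amide-type nitrogen. Going by the values given here, the one measured step at that nitrogen is a step that the two limits leave unreadable from compound 2 to compound 3 and offers no size to carry over. The expected outcome is a number no higher from compound 3 to compound 4 (the limit leaves the size open) in this assay with no direction foreseen and another limit the likely report. The estimate for compound 4 is 100000 nM with an expected range of 50000 nM to 200000 nM here.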

Compound 4, half-maximal inhibitory concentration: > 100000 nM
Compound 4 was reported as a limit; the forecaster's own chance of this, stated with the estimate: 90%; the middle value lies on the limit itself.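

No step can be read among compounds 1, 2, 3 and 4, since each is reported only as a limit: the limit of > 100000 nM in this assay, at which 4 of the 4 values shown sit.

Left open is whether the group on the amide-type nitrogen or the configuration as drawn affects cytotoxicity at all, including for the pair concerned here: the fact that compounds 1 and 4 differ only in the configuration as drawn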